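The source may hold more compounds than are shown below. What is called first, only, known or untested is meant among the compounds shown, and "the series" means these compounds.

Three compounds share one core and differ only in the group attached to a carbonyl carbon. In a functional assay on MCF7 cells (Homo sapiens) for cytotoxicity, read by MTT assay, with a stated time of 72 h (a lower number here means a stronger inhibitor, a higher number a weaker inhibitor), compound 1 `COc1cc2ncnc(NNC(=S)NC(=O)c3ccc(C(F)(F)F)cc3)c2cc1OC` gives 16800 nM, compound 2 `COc1cc2ncnc(NNC(=S)NC(=O)c3ccccc3C)c2cc1OC` gives 19300 nM, and compound 3 `O=C(NC(=S)NNc1ncnc2ccccc12)c1ccc(C(F)(F)F)cc1` gives 8050 nM. Compound 2 has the highest of the three numbers; compound 1 sits within the scatter of it, while compound 3 shows a lower number beyond the scatter. Compound 4 `COc1cc2ncnc(NNC(=S)NC(=O)c3ccc(F)cc3)c2cc1OC` carries 4-fluorophenyl in place of 2-methylphenyl on a carbonyl carbon. Among the measured compounds shown here, the one measured step of the same kind, a 1.1-fold higher number from compound 1 to compound 2 (0.06 log units; within the scatter), stayed within the scatter, so a step of little size in this assay is expected, with no clear direction. Compound 4 is therefore estimated at 17000 nM, with a range from 8000 nM to 36000 nM, which means an expected step of a 1.1-fold lower number from compound 2 to compound 4 (0.06 log units; within the scatter).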

Compound 4, half-maximal inhibitory concentration: 25800 nM
Estimate against measurement, compound 4: 1.5-fold (0.18 log units) below, within the range that was stated.
By their numbers in this assay, from the lowest: compound 3; then compounds 1, 2 and 4 (each within the scatter of the next).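

With a 1.3-fold higher number from compound 2 to compound 4 (0.13 log units; within the scatter) for 4-fluorophenyl in place of 2-methylphenyl and a 1.5-fold higher number from compound 1 to compound 4 (0.19 log units; within the scatter) for fluoro in place of trifluoromethyl on an aromatic carbon, all three groups on this carbonyl carbon now lie within the scatter of one another in this assay. A third group therefore adds to the flat picture that one step could only hint at. Nothing measured here accounts for this flatness. Still open, as far as these compounds go, is whether a phenyl ring carrying an amine or a carboxylic acid, or a cyclohexyl group, would read differently here. Also open, from the compounds shown here alone, is how 4-fluorophenyl would read on the core of compound 3.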